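Methoxy in place of hydroxy on the aryl oxalamide

The compounds below may be only part of what the source reports. "The series", "measured", "known", "first", "only" and "open" are said of these compounds alone.

For the measured compounds named here, compound 3 `O=C(Nc1ccc(O)cc1)C(=O)Nc1ccc2c(c1)COC2=O` gives 5030 nM in a functional assay on cells (T-cell, Mus musculus) for inhibition (a lower number here means a stronger inhibitor, a higher number a weaker inhibitor), the highest of the three numbers measured so far. Compound 1 `CC(C)(C)NC(=O)C(=O)Nc1ccc2c(c1)COC2=O` gives 3400 nM and compound 2 `O=C(Nc1ccc(Cl)cc1)C(=O)Nc1ccc2c(c1)COC2=O` gives 2240 nM. Of the steps among them, only a 2.2-fold higher number from compound 2 to compound 3 (0.35 log units; beyond the scatter) lies beyond the scatter; a 1.5-fold higher number from compound 1 to compound 3 (0.17 log units; within the scatter) and a 1.5-fold lower number from compound 1 to compound 2 (0.18 log units; within the scatter) do not.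

Compound 4 `COc1ccc(NC(=O)C(=O)Nc2ccc3c(c2)COC3=O)cc1` differs from compound 3 by methyl in place of hydrogen on an oxygen on an aromatic ring. Going by the values given here, no measured step exchanges hydroxy for methoxy, so the expectation rests on the spread among compounds 1, 2 and 3. The step that bears most directly is a 2.2-fold higher number from compound 2 to compound 3 (0.35 log units; beyond the scatter), which shows that exchanging the group on this aromatic carbon can shift the number beyond the scatter, with hydroxy on the high side. The step of a 1.5-fold higher number from compound 1 to compound 3 (0.17 log units; within the scatter) shows that a 4-hydroxyphenyl and a tert-butyl sit within the scatter of each other. Since compound 3 holds the highest number and the other two groups at this place gave lower numbers, the expected outcome is a 1.7-fold lower number from compound 3 to compound 4 (0.22 log units; within the scatter), a modest move toward the numbers of compounds 1 and 2 rather than a further rise. Compound 4 is therefore estimated at 3000 nM, with a range from 1200 nM to 7500 nM.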

Compound 4, half-maximal inhibitory concentration: 153000 nM
Compound 4: middle estimate off by 51-fold (1.71 log units), on the low side; measured number above the stated range.
By their numbers in this assay, from the lowest: compounds 2, 1 and 3 (each within the scatter of the next, the first and the last beyond it); then compound 4.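

In this assay, for the compounds shown here, the oxygen on the aromatic ring turns out to be far more sensitive than the earlier compounds suggested: methyl in place of hydrogen there gives a 30-fold higher number from compound 3 to compound 4 (1.48 log units; beyond the scatter) in a series whose earlier steps were modest or within the scatter. The 4-methoxyphenyl group also stands well apart from the other two groups at this place, with a 68-fold higher number from compound 2 to compound 4 (1.83 log units; beyond the scatter) and a 45-fold higher number from compound 1 to compound 4 (1.65 log units; beyond the scatter) on the same side, which makes compound 4 the weakest inhibitor of the four. A single added methyl therefore does far more here than the much larger exchange of tert-butyl for 4-hydroxyphenyl, which gives only a 1.5-fold higher number from compound 1 to compound 3 (0.17 log units; within the scatter) and so stays within the scatter.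

As far as these compounds go, whether so large a rise belongs to methoxy alone or extends to ethoxy, or whether an amine or a carboxylic acid on the same aromatic carbon would stay with the lower numbers, remains open. Nothing in the data at hand accounts for the size of this jump.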